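Fluoro for hydrogen on the isatin-type core, compound 1 to compound 4

A few compounds are considered here, and "the series" means these few. Any claim that something is new, unique, unknown or untested is made for them only; others in the source may bear on it.

Measured compounds:
compound 1 `O=C1C(=O)N(CC(CO)NCCCCNc2ccnc3cc(Cl)ccc23)c2ccccc21` — 37%
compound 2 `O=C1C(=O)N(CC(CO)NCCCNc2ccnc3cc(Cl)ccc23)c2ccc(Cl)cc21` — 46%
compound 3 `O=C1C(=O)N(CC(CO)NCCNc2ccnc3cc(Cl)ccc23)c2ccc(Cl)cc21` — 88%

The three measured compounds share a core and a chain carrying the chloroquinoline end, and were read in an ADME assay on HCT-116 cells (Homo sapiens) for cytotoxicity, read by MTT assay, with a stated time of 48 h, tested at 20 uM; on this read-out higher numbers stand for a stronger effect at the one concentration tested and lower numbers for a weaker effect. Compound 1 stands lowest of the three numbers. Compound 2 is nearest, a number within the scatter of that of compound 1, so the two cannot be ordered. Compound 3 is furthest, with a number well beyond the scatter above compound 1. Among the measured compounds shown here, compound 2 and compound 3 each differ from compound 1 in more than one place, so no single-point step among the measured compounds is available.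

Compound 4 `O=C1C(=O)N(CC(CO)NCCCCNc2ccnc3cc(Cl)ccc23)c2ccc(F)cc21` is not yet measured. From compound 1 the change is fluoro in place of hydrogen on an aromatic carbon.

With no measured step of this kind in the series, the expectation rests on the value of compound 1 alone. Because compound 1 gives 37% and the change is a single small atom swap, the step of a number 5 percentage points higher from compound 1 to compound 4 (within the scatter) is expected to be small, if anything slightly upward, and most likely not beyond the scatter. Compound 4 is estimated at 42%, with a range from 25% to 65%.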

Compound 4, a percentage reported as inhibition, at one concentration (the size of the read-out at that concentration, not a potency): 83%
The estimate for compound 4 lay 41 percentage points below the measured number; the whole stated range lies below it.
By their numbers in this assay, from the lowest: compounds 1 and 2 (each within the scatter of the next); then compounds 4 and 3 (each within the scatter of the next).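

In this assay, fluoro in place of hydrogen on an aromatic carbon of the shared core, meta to a fused ring and para to a fused ring, gives a number 46 percentage points higher from compound 1 to compound 4 (beyond the scatter), the first single-point step available in the series. The read-out therefore responds strongly at this position to the entry of 1 heavy atom, with no ring, no hydrogen-bond donors or acceptors and no net charge added, while the chain and the chloroquinoline end stay as in compound 1. Nothing in hand bears on the origin of a step of this size.

As far as these compounds go, it remains open whether the step is particular to fluoro or is shared by other groups on the same aromatic carbon, such as methyl, methoxy or nitrile, and whether fluoro in place of hydrogen gives a step of similar size on the chains of compound 2 and compound 3. With this assay reporting the size of the effect at one concentration, the step shows a stronger effect for compound 4 than for compound 1 at that concentration and leaves open how the two compare at any other concentration.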